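Aryl variation on the shared core: toward compound 4

The source may report more compounds than this note shows. Statements on the series, on what has been measured and on what is new or still open speak of the compounds shown alone.

Measured so far in a functional assay on HepG2 cells (Homo sapiens) for cytotoxicity, read by sulforhodamine B assay, with a stated time of 48 h; a lower number here means a stronger inhibitor, a higher number a weaker inhibitor:
- compound 1 `CCOC(=O)c1c(-c2ccccc2)c(C#N)c(=O)n(/N=C(\C)c2ccc(NS(=O)(=O)c3ccc(Cl)cc3)cc2)c1N` gives 16800 nM
- compound 2 `CCOC(=O)c1c(-c2ccccc2Cl)c(C#N)c(=O)n(/N=C(\C)c2ccc(NS(=O)(=O)c3ccc(Cl)cc3)cc2)c1N` gives 11400 nM
- compound 3 `CCOC(=O)c1c(-c2ccc(N(C)C)cc2)c(C#N)c(=O)n(/N=C(\C)c2ccc(NS(=O)(=O)c3ccc(Cl)cc3)cc2)c1N` gives 21000 nM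

Compound 3 carries the highest of the three numbers in this assay, but the steps that lead to it, a 1.3-fold higher number from compound 1 to compound 3 (0.10 log units; within the scatter) and a 1.8-fold higher number from compound 2 to compound 3 (0.27 log units; within the scatter), both lie within the scatter, so the three compounds cannot be put in order on these data.

Compound 4 `CCOC(=O)c1c(-c2cccc([N+](=O)[O-])c2)c(C#N)c(=O)n(/N=C(\C)c2ccc(NS(=O)(=O)c3ccc(Cl)cc3)cc2)c1N` is the next member. The change from compound 3 is 3-nitrophenyl in place of 4-(dimethylamino)phenyl on an aromatic carbon. Within the data shown here, the steps that bear on it are those that alter the same aryl group on the core: a 1.5-fold lower number from compound 1 to compound 2 (0.17 log units; within the scatter), a 1.3-fold higher number from compound 1 to compound 3 (0.10 log units; within the scatter) and a 1.8-fold higher number from compound 2 to compound 3 (0.27 log units; within the scatter). None of them moves the number in this assay beyond the scatter, whether a hydrogen, a chloro or a dimethylamino group sits on that ring. Among the measured compounds shown here, the 3-nitrophenyl group has not been tested, so there is no direct precedent. Given the flat response to the aryl changes made so far, compound 4 is expected to stay close to compound 3, with a step of a 1.4-fold lower number from compound 3 to compound 4 (0.15 log units; within the scatter) in this assay and no change beyond the scatter. The estimate for compound 4 in this assay is 15000 nM, in a range from 6000 nM to 38000 nM.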

Compound 4, half-maximal inhibitory concentration: 29700 nM
Beside the measured number, compound 4's estimate is 2.0-fold (0.30 log units) below it; measured number inside the range.
By their numbers in this assay, from the lowest: compounds 2, 1, 3 and 4 (each within the scatter of the next, the first and the last beyond it).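

In this assay, among these compounds, 3-nitrophenyl gives the first step at this aryl position that passes the scatter, though only a modest one and only against 2-chlorophenyl (a 2.6-fold higher number from compound 2 to compound 4 (0.42 log units; beyond the scatter)). The other two steps stay within the scatter (a 1.8-fold higher number from compound 1 to compound 4 (0.25 log units; within the scatter); a 1.4-fold higher number from compound 3 to compound 4 (0.15 log units; within the scatter)), so compound 4 cannot be separated from compound 1 or compound 3, and the position is not wholly flat only in that compound 2 and compound 4 now stand apart. No measurement shown accounts for the gap between this pair.

Going by these compounds, with a single nitro-bearing and a single chloro-bearing aryl group in view, it remains open whether the gap follows the nitro group, its place on the phenyl ring or the removal of 2-chlorophenyl. On these data alone, it also remains open how a carboxylic acid, a primary amine or a methoxy group on the same phenyl ring would read, and whether any such group would move the number beyond the scatter from compound 1.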